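Carbamoylmethyl for 4-methylphenyl: working notes on compound 3

The source may hold more compounds than are shown below. What is called first, only, known or untested is meant among the compounds shown, and "the series" means these compounds.

In a functional assay on THP-1 cells (Homo sapiens) for cytotoxicity, read by MTT assay, with a stated time of 24 h (a higher number here means a weaker inhibitor, a lower number a stronger inhibitor), compound 1 `Cc1ccc(-n2cc(Cn3nc(N)c4c(C(F)(F)F)cc(-c5ccccc5)nc43)nn2)cc1` gives 98.6 ug/mL, within the scatter of compound 2 `COc1ccc(NC(=O)Cn2cc(Cn3nc(N)c4c(C(F)(F)F)cc(-c5ccccc5)nc43)nn2)cc1` at 56.7 ug/mL. Compound 3 `Nc1nn(Cc2cn(CC(=O)Nc3ccc(F)cc3)nn2)c2nc(-c3ccccc3)cc(C(F)(F)F)c12` carries ((4-fluorophenyl)carbamoyl)methyl in place of 4-methylphenyl on an aromatic nitrogen. Among the measured compounds shown here, the one measured step bearing on this change is a 1.7-fold lower number from compound 1 to compound 2 (0.24 log units; within the scatter), where ((4-methoxyphenyl)carbamoyl)methyl enters at the same place. For the measured compounds named here, only that single step supports the expectation, and it stays within the scatter. The expected change, a 1.6-fold lower number from compound 1 to compound 3 (0.20 log units; within the scatter), is therefore none beyond the scatter. Compound 3 is estimated at 62 ug/mL, with an expected range of 28 ug/mL to 135 ug/mL.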

Compound 3, half-maximal inhibitory concentration: 49.6 ug/mL
Estimate against measurement, compound 3: 1.3-fold (0.10 log units) above; measured number inside the range.
By their numbers in this assay, from the lowest: compounds 3, 2 and 1 (each within the scatter of the next).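

In this assay the entry of ((4-fluorophenyl)carbamoyl)methyl on the aromatic nitrogen gives a 2.0-fold lower number from compound 1 to compound 3 (0.30 log units; within the scatter) and so a second carbamoylmethyl group, with a different aromatic substituent, also stays inside the scatter against 4-methylphenyl. Fluoro in place of methoxy on the aromatic carbon gives a 1.1-fold lower number from compound 2 to compound 3 (0.06 log units; within the scatter) and is the first reading of a change on that aromatic ring, which leaves the number within the scatter too. No measured evidence bears on what lies behind these numbers.

The compounds shown leave open whether an amine or a carboxylic acid on that aromatic carbon would move the number beyond the scatter. Going by these compounds, whether a longer chain in place of the carbamoylmethyl link would do so also remains open.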